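From 1H-pyrazol-4-yl to 1-hydroxy-2,2-dimethylpropyl on the carbonyl

This account rests on a few compounds, and the source may have more. Where it says the series, first, only, none or still open, it means among the compounds named here.

Measured compounds:
Compound 1, `Cc1ccc(C(=O)Nc2sc3c(c2C(N)=O)CCCC3)s1`, 652 nM
Compound 2, `CC1(C)Cc2c(sc(NC(=O)c3ccccc3O)c2C(N)=O)CO1`, 13 nM
Compound 3, `CC1(C)Cc2c(sc(NC(=O)c3cn[nH]c3)c2C(N)=O)C(C)(C)O1`, 125 nM

In an assay on cells for positive allosteric modulation of Cystic fibrosis transmembrane conductance regulator variant F508del (Homo sapiens), with stated times of 10 min and 7 s, in the presence of a further agent that is not named here (on this read-out higher numbers stand for an effect only at larger amounts of compound and lower numbers for an effect already at smaller amounts), compound 3 stands second highest of the three numbers. Its nearest neighbour is compound 1, whose value lies beyond the scatter above it; compound 2 is furthest away, beyond the scatter below it. Compound 2 therefore shows the lowest number of the three, and compound 1 the highest.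

The next compound, compound 4, `CC1(C)Cc2c(sc(NC(=O)[C@@H](O)C(C)(C)C)c2C(N)=O)C(C)(C)O1`, keeps the core of compound 3 and changes only the group on the carbonyl carbon: 1-hydroxy-2,2-dimethylpropyl in place of 1H-pyrazol-4-yl on a carbonyl carbon. Going by the values given here, no pair of measured compounds shares this difference, so the step can only be expected from the three values shown. Between compound 3 and compound 2 the group on the carbonyl moved from a five-membered aromatic ring to a six-membered aromatic ring with a hydroxyl, and the number fell; here the ring is lost altogether. Compound 4 is expected to give a modest step of a 2.0-fold higher number from compound 3 to compound 4 (0.30 log units; within the scatter) toward a higher number, though the range is wide. The value of compound 4 in this assay is estimated at 250 nM, between 60 nM and 1000 nM.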

Compound 4, half-maximal effective concentration: 2.7 nM
Compound 4: the middle estimate sits 93-fold (1.97 log units) above what was measured; the whole stated range lies above it.
By their numbers in this assay, from the lowest: compound 4; then compound 2; then compound 3; then compound 1.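

In this assay, putting 1-hydroxy-2,2-dimethylpropyl in place of 1H-pyrazol-4-yl on the carbonyl carbon gives a 46-fold lower number from compound 3 to compound 4 (1.67 log units; beyond the scatter), a large step. This shows that an aromatic ring is not required at this position: compound 4, whose group has no ring, reaches 2.7 nM. The two groups have the same count of hydrogen-bond donors and acceptors, so that count does not separate them, and no supporting evidence bears on the reason for the size of the step.

The compounds shown leave open whether the hydroxyl, the branched carbon chain or both go with the lower number. Also open, on these data alone, is how an amine in place of the hydroxyl, or the opposite configuration at the defined stereocentre, would read in this assay.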